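A few compounds are considered here, and "the series" means these few. Any claim that something is new, unique, unknown or untested is made for them only; others in the source may bear on it.

In a physicochemical assay for lipophilicity, at pH 7.4 (on this read-out higher numbers stand for higher lipophilicity and lower numbers for lower lipophilicity), compound 1 `CC(C)CN(c1cc2ccccc2s1)S(=O)(=O)c1ccc2c(c1)C(O)CC(C1CCOCC1)O2` gives 3.92 and stands lowest of the two numbers in hand, with compound 2 `CCc1ccc(N(CC(C)C)S(=O)(=O)c2ccc3c(c2)C(OC2CCCCC2)CC(C2CCOCC2)O3)cc1` at 6.28 and clear of the scatter above it. Compound 3 `CC(C)CN(c1ccc(F)cc1F)S(=O)(=O)c1ccc2c(c1)C(O)CC(C1CCOCC1)O2` differs from compound 1 by one change 2,4-difluorophenyl in place of 1-benzothiophen-2-yl on a sulfonamide nitrogen on a sulfonamide nitrogen, 2,4-difluorophenyl in place of 1-benzothiophen-2-yl. Within the data shown here, no measured pair shows this change on its own. The expected step is a modest fall, estimated as a number 0.42 log units lower from compound 1 to compound 3 (beyond the scatter) in this assay and only just beyond the scatter. For compound 3 the estimated value is 3.5 with an expected range of 3 to 4 pending measurement.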

Compound 3, distribution coefficient: 3.53
For compound 3 the middle estimate is 0.03 log units below the measured one; low and high end bracket the measured number.
By their numbers in this assay, from the lowest: compound 3; then compound 1; then compound 2.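

Among these compounds, the pair compound 1 and compound 3 gives the first single-change reading at the sulfonamide nitrogen: in this assay, 2,4-difluorophenyl in place of 1-benzothiophen-2-yl gives a number 0.39 log units lower from compound 1 to compound 3 (beyond the scatter) and counts as a modest step. The position therefore responds measurably when a single six-membered aromatic ring replaces the two-ring group. No measurement at hand accounts for this step.

One pair cannot separate the contributions of the sulfur, the second ring and the two fluorines. From the compounds shown here alone, how this read-out responds to a phenyl ring carrying an amine or a carboxylic acid at this nitrogen remains open.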